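The source may hold more compounds than are shown below. What is called first, only, known or untested is meant among the compounds shown, and "the series" means these compounds.

For the measured compounds named here, compound 2 `COc1cc(C(=O)c2ccc3c(ccn3S(=O)(=O)c3cccc(/C=C/C(=O)NO)c3)c2)cc(OC)c1OC` gives 1260 nM in an assay on isolated protein for inhibition of histone deacetylase 8 (Homo sapiens) (on this read-out higher numbers stand for weaker inhibition and lower numbers for stronger inhibition), the lowest of the two numbers so far. Going by the values given here, compound 1 `COc1cc(C(=O)c2ccc3c(ccn3S(=O)(=O)c3ccc(/C=C/C(=O)NO)cc3)c2)cc(OC)c1OC` gives 5340 nM in this assay, and the only measured step, a 4.2-fold lower number from compound 1 to compound 2 (0.63 log units; beyond the scatter), concerns the position of the hydroxycarbamoylethenyl group on the sulfonyl sulfur. Compound 3 `COc1ccc(C(=O)c2ccc3c(ccn3S(=O)(=O)c3cccc(/C=C/C(=O)NO)c3)c2)cc1` alters a different part of the molecule: 4-methoxyphenyl in place of 3,4,5-trimethoxyphenyl on a carbonyl carbon. Among the compounds with values here, no measured step touches the aryl on the carbonyl carbon, so nothing supports a step in this assay beyond the scatter, although the change from 3,4,5-trimethoxyphenyl to 4-methoxyphenyl leaves room for a somewhat higher number. Compound 3 is expected at 1600 nM, within 500 nM to 5000 nM, an expected step of a 1.3-fold higher number from compound 2 to compound 3 (0.10 log units; within the scatter).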

Compound 3, half-maximal inhibitory concentration: 812 nM
Beside the measured number, compound 3's estimate is 2.0-fold (0.29 log units) above it; low and high end bracket the measured number.
By their numbers in this assay, from the lowest: compounds 3 and 2 (each within the scatter of the next); then compound 1.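

For the compounds shown here, replacing 3,4,5-trimethoxyphenyl with 4-methoxyphenyl on the carbonyl carbon gives a 1.6-fold lower number from compound 2 to compound 3 (0.19 log units; within the scatter) in this assay and is the first read on this part of the molecule. In this pair, the step stays inside the scatter, so 3,4,5-trimethoxyphenyl is not needed to keep the number in this range. No evidence on hand bears on this result.

Still open, as far as these compounds go, is whether a plain phenyl or a dimethylamino-substituted phenyl on the carbonyl carbon would also stay within the scatter. From the compounds shown here alone, it is also open whether the step seen on moving the hydroxycarbamoylethenyl group holds with 4-methoxyphenyl in place.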